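Benzimidazole-type series, paw edema inhibition at one oral dose

The compounds below may be only part of what the source reports. "The series", "measured", "known", "first", "only" and "open" are said of these compounds alone.

Measured so far:
compound 1, `COc1cccc(-c2nc3cc(C)ccc3[nH]2)n1`: 32%
compound 2, `Cc1ccc(-c2nc3ccccc3n2CCN(C)C)nc1`: 12%

In a functional assay on the whole organism with Rattus norvegicus as the target, read by paw edema, with a stated time of 3 h, at a dose of 100 mg/kg by the oral route (a lower number here means less inhibition, a higher number more inhibition at the dose given (going by the name of the read-out)), compound 1 gives 32%. Compound 2 gives 12%, the lower of the two numbers, with compound 1 standing higher by a gap beyond the usual scatter.

Compound 3, `Cc1ccc(-c2nc3ccccc3n2CC(=O)N2CCCC2)nc1`, is not yet measured. It differs from compound 2 by (pyrrolidin-1-yl)carbonyl in place of (dimethylamino)methyl on a saturated chain carbon bound to an aromatic nitrogen. Among the compounds with values here, no measured pair shows this change, so the direction is open. The step from compound 2 to compound 3 is expected to be small, likely within the scatter: a number 6 percentage points higher from compound 2 to compound 3 (within the scatter). Compound 3 is thus estimated at 18%, with a range from 2% to 38%.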

Compound 3, a percentage reported as inhibition, in the whole organism at one dose (the size of the read-out at that dose, not a potency): 14%
Compound 3: middle estimate off by 4 percentage points, on the high side; measured number inside the range.
By their numbers in this assay, from the lowest: compounds 2 and 3 (each within the scatter of the next); then compound 1.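

In this assay, (pyrrolidin-1-yl)carbonyl in place of (dimethylamino)methyl on a saturated chain carbon bound to an aromatic nitrogen gives a number 2 percentage points higher from compound 2 to compound 3 (within the scatter). This first step at this place therefore does not separate the two compounds, despite the added ring and carbonyl. Nothing measured bears on this result.

Still open, on these data alone, is how a carboxylic acid or a longer chain at this place would read in this assay. Also open, as far as these compounds go, is whether a piperidine amide would stay within the scatter of compound 3.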